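The compounds below may be only part of what the source reports. "The series", "measured", "known", "first", "only" and "open" are said of these compounds alone.

Measured compounds in an assay on HEK293 cells for displacement of a labelled ligand from NPC1-like intracellular cholesterol transporter 1 (Homo sapiens); on this read-out lower numbers stand for stronger inhibition and higher numbers for weaker inhibition:
compound 1 `CC(C)(C)c1ccc(C(=O)N2CCC3(CC2)C(=O)N(CC(=O)N2CCNCC2)CN3c2ccccc2)cc1`: 22000 nM
compound 2 `CC(C)(C)OC(=O)NCCNC(=O)CN1CN(c2ccccc2)C2(CCN(C(=O)c3ccc(C(C)(C)C)cc3)CC2)C1=O`: 10900 nM
compound 3 `CC(C)(C)c1ccc(C(=O)N2CCC3(CC2)C(=O)N(CC(=O)N2CCC(O)CC2)CN3c2ccccc2)cc1`: 4700 nM

Compound 2 stands second highest of these three numbers. Its step to compound 1 lies within the scatter, a 2.0-fold lower number from compound 1 to compound 2 (0.30 log units; within the scatter), while its step to compound 3 is modest but beyond it, a 2.3-fold lower number from compound 2 to compound 3 (0.37 log units; beyond the scatter); the step from compound 1 to compound 3 is the largest, a 4.7-fold lower number from compound 1 to compound 3 (0.67 log units; beyond the scatter). All three steps alter the group on the carbonyl carbon.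

Compound 4 `CC(C)(C)OC(=O)NCCNC(=O)CN1CN(c2ccccc2)C2(CCN(C(=O)c3ccc(C4CCCCC4)cc3)CC2)C1=O` differs from compound 2 elsewhere: cyclohexyl in place of tert-butyl on an aromatic carbon. Among the compounds with values here, no measured step touches this aromatic carbon, so no measured step bears on the change. With nothing to argue for a direction, the expected step in this assay is a 1.1-fold lower number from compound 2 to compound 4 (0.04 log units; within the scatter), likely none beyond the scatter. Compound 4 is therefore estimated at 10000 nM, with a wide range from 3000 nM to 35000 nM.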

Compound 4, half-maximal inhibitory concentration: 5500 nM
The estimate for compound 4 lay 1.8-fold (0.26 log units) above the measured number, within the range that was stated.
By their numbers in this assay, from the lowest: compounds 3, 4, 2 and 1 (each within the scatter of the next, the first and the last beyond it).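

Within the data shown here, this is the first reading at the aromatic carbon para to a large group: 4-(tert-butyl)phenyl to 4-cyclohexylphenyl gives, in this assay, a 2.0-fold lower number from compound 2 to compound 4 (0.30 log units; within the scatter). Six carbon heavy atoms and a six-membered non-aromatic ring therefore stand in place of four carbon heavy atoms and no ring, with the step remaining within the scatter. Nothing available explains this result.

Still open, going by these compounds, is whether an amine or a carboxylic acid on this aromatic carbon would keep the number within the scatter. Also open, on these data alone, is whether cyclohexyl gives a similar step alongside 4-hydroxypiperidin-1-yl on the carbonyl carbon.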